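The compounds below may be only part of what the source reports. "The series", "measured", "known", "first", "only" and "open" are said of these compounds alone.

Among the compounds with values here, in a functional assay on T98G cells (Homo sapiens) for inhibition, read by MTT assay, with a stated time of 72 h (on this read-out higher numbers stand for weaker inhibition and lower numbers for stronger inhibition), three compounds built on one shared core have numbers so far. Compound 3 (`CC1(C)CC(NC(=O)Nc2ccc(Cl)cc2)c2cc(Cl)ccc2O1`) gives 33000 nM and compound 1 (`CC1(C)CC(NC(=O)Nc2ccc(Cl)cc2)c2cc(F)ccc2O1`) gives 30000 nM, so these two stand level within the scatter, together at the high-number, weaker end of what has been seen. Compound 2 (`CC1(C)CC(NC(=O)Nc2ccccc2Cl)c2cc(Br)ccc2O1`) gives 11000 nM, a lower number than compound 3 shows.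

The next compound, compound 4 (`CC1(C)CC(NC(=O)Nc2ccc(Cl)cc2)c2cc(Br)ccc2O1`), is still unmeasured. It departs from compound 3 in a single exchange, bromo in place of chloro on an aromatic carbon.

Within the data shown here, one measured step bears directly on this exchange: chloro in place of fluoro at the same place, which is a 1.1-fold higher number from compound 1 to compound 3 (0.04 log units; within the scatter). Compound 2 also carries bromo, but its chloro group sits elsewhere than in compound 4, so its lower value is no clean guide, though it leaves some room on the low side. On the evidence of the step to compound 3 from compound 1, no step beyond the scatter is expected in this assay. The estimated change is a 1.2-fold lower number from compound 3 to compound 4 (0.07 log units; within the scatter). For compound 4 the estimated value is 28000 nM, with an expected range from 14000 nM to 55000 nM.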

Compound 4, half-maximal inhibitory concentration: 27000 nM
Compound 4: middle estimate off by 1.0-fold (0.02 log units), on the high side, within the range that was stated.
By their numbers in this assay, from the lowest: compound 2; then compounds 4, 1 and 3 (each within the scatter of the next).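

In this assay, within the data shown here, bromo in place of chloro on this aromatic carbon of the fused system stays within the scatter (a 1.2-fold lower number from compound 3 to compound 4 (0.09 log units; within the scatter)), and so does bromo in place of fluoro (a 1.1-fold lower number from compound 1 to compound 4 (0.05 log units; within the scatter)), so with the 4-chlorophenyl group held fixed, fluoro, chloro and bromo now stand level at this place, where the earlier compounds had offered only the fluoro and chloro pair. Among these compounds, compound 4 also gives the first clean comparison at the other place: with bromo held fixed, 4-chlorophenyl in place of 2-chlorophenyl on an amide-type nitrogen gives a modest step beyond the scatter (a 2.5-fold higher number from compound 2 to compound 4 (0.39 log units; beyond the scatter)), which shows that the lower number of compound 2 goes with this exchange and not with the bromo group, which both compounds carry. No measurement shown here offers an explanation for either result.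

From the compounds shown here alone, it remains open whether something other than a halogen at this place, such as a methoxy group or an amine, would shift the number in this assay. Going by these compounds, it is also open whether the exchange between 2-chlorophenyl and 4-chlorophenyl gives a similar step when fluoro or chloro stands in place of bromo.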